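Dimethylpyrazole in place of pyrazole: working notes

The source may hold more compounds than are shown below. What is called first, only, known or untested is meant among the compounds shown, and "the series" means these compounds.

- compound 1 `CCN(CC)CCCS(=O)(=O)c1ccc2nc(NC(=O)NC(=O)c3cc(-n4cccn4)ccc3Cl)sc2c1`: 1600 nM
- compound 2 `CN1CCN(CCCS(=O)(=O)c2ccc3nc(NC(=O)NC(=O)c4cc(-n5cccn5)ccc4Cl)sc3c2)CC1`: 1200 nM
- compound 3 `CN1CCN(CCCS(=O)(=O)c2ccc3nc(NC(=O)NC(=O)c4cc(-n5cccn5)c(Cl)cc4Cl)sc3c2)CC1`: 30 nM
- compound 4 `Cc1cc(C)n(-c2ccc(Cl)c(C(=O)NC(=O)Nc3nc4ccc(S(=O)(=O)CCCN5CCN(C)CC5)cc4s3)c2)n1`: not yet measured

All values come from an ADME assay on the whole organism (strain Han-Wistar) for pharmacokinetics, with Rattus norvegicus as the target, read by LC-MS, at a dose of 2 mg/kg by the oral route; a higher number here means more compound in the circulation at the dose given, a lower number less compound in the circulation. Compound 2, at 1200 nM, shares the top of the three numbers with compound 1, the difference being a 1.3-fold lower number from compound 1 to compound 2 (0.12 log units; within the scatter). Compound 3 lies far from both.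

Compound 4 differs from compound 2 as follows: 3,5-dimethyl-1H-pyrazol-1-yl in place of 1H-pyrazol-1-yl on an aromatic carbon. The change sits on an aromatic carbon, para to a chloro group.

The most relevant measured change is a 40-fold lower number from compound 2 to compound 3 (1.60 log units; beyond the scatter), which also adds to a six-membered aromatic ring of carbon only. It is a single example with a different group, so it suggests a direction but not a size. The change on the saturated chain, a 1.3-fold lower number from compound 1 to compound 2 (0.12 log units; within the scatter), lies elsewhere and says little here. Going by the values given here, no measured step tests methyl groups on the pyrazole.

The expected change is a moderate one, much smaller than the chloro step: a 2.0-fold lower number from compound 2 to compound 4 (0.30 log units; within the scatter). For compound 4 the estimate is 600 nM, with an expected range of 150 nM to 1800 nM.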

Compound 4, maximal plasma concentration: 78 nM
Estimate against measurement, compound 4: 7.7-fold (0.89 log units) above; the measured number lies below the stated range.
By their numbers in this assay, from the lowest: compound 3; then compound 4; then compounds 2 and 1 (each within the scatter of the next).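

In this assay, the group on the aromatic carbon para to a chloro group proves to be a sensitive place: 3,5-dimethyl-1H-pyrazol-1-yl in place of 1H-pyrazol-1-yl gives a 15-fold lower number from compound 2 to compound 4 (1.19 log units; beyond the scatter) on the same shared core. The earlier compounds shown here all carry 1H-pyrazol-1-yl, so they could not show that two added methyl groups on this ring are enough for a step beyond the scatter, in the same direction as a 40-fold lower number from compound 2 to compound 3 (1.60 log units; beyond the scatter) but at a different place. Nothing measured here bears on why the number falls.

From the compounds shown here alone, whether a single methyl group on the pyrazole would give a step of similar size remains open. Also open, going by these compounds, is how an ethyl group or a trifluoromethyl group on the pyrazole, or a morpholine in its place, would read in this assay on this core.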